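This account rests on a few compounds, and the source may have more. Where it says the series, first, only, none or still open, it means among the compounds named here.

Measured so far in a physicochemical assay for metabolic stability, read by HPLC and mass spectrometry, in phosphate buffer, at 37 degrees C, at pH 7.4; on this read-out higher numbers stand for a longer-lived compound and lower numbers for a shorter-lived compound:
- compound 1 `CC(C)(O/N=C(\C(=O)N[C@@H]1C(=O)N(S(=O)(=O)O)[C@@H]1Cn1ccnn1)c1csc(N)n1)C(=O)O`: 257 h
- compound 2 `CC(C)(O/N=C(\C(=O)N[C@@H]1C(=O)N(S(=O)(=O)O)[C@@H]1CN1C[C@@H](CN)OC1=O)c1csc(N)n1)C(=O)O`: > 37 h (a limit)
- compound 3 `CC(C)(O/N=C(\C(=O)N[C@@H]1C(=O)N(S(=O)(=O)O)[C@@H]1Cn1ncnc1CN)c1csc(N)n1)C(=O)O`: > 37 h (a limit)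

For compound 3 the reading of > 37 h is a limit and not a number. This is the limit of > 37 h in this assay, at which 2 of the 3 values shown sit, so compound 3 has no exact place in the series.

Compound 4 `CC(C)(O/N=C(\C(=O)N[C@@H]1C(=O)N(S(=O)(=O)O)[C@@H]1Cn1ncnc1CNC(=N)N)c1csc(N)n1)C(=O)O` differs from compound 3 by a group of 3 heavy atoms (1 carbon, 2 nitrogen; no ring) in place of a hydrogen atom, on an amine nitrogen, on an amine nitrogen whose other neighbour is a saturated chain carbon.

The measured steps that come nearest are a step that the limit leaves unreadable from compound 1 to compound 3 and a step that the two limits leave unreadable from compound 2 to compound 3, alongside a step that the limit leaves unreadable from compound 1 to compound 2. Each exchanges the whole group on a saturated chain carbon, and none repeats this change on the amine nitrogen. They offer no size and no direction to carry over, so no direction is expected in this assay. The expected change is a step that the limit leaves unreadable from compound 3 to compound 4, and it is only a loose estimate.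

For compound 4 the estimated half-life is 80 h, with an expected range from 25 h to 300 h, and a limit may well be reported again.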

Compound 4, half-life: > 37 h
Compound 4: a limit, no number (the forecaster's own chance of this, stated with the estimate: 60%); the middle value lies beyond the limit too.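

In this assay compound 4 gives > 37 h, a limit and not a number. No new step to compound 4 from compound 1, compound 2 or compound 3 can be read: the limit of > 37 h in this assay, at which 3 of the 4 values shown sit.

The compounds shown leave open how the half-lives of compound 2, compound 3 and compound 4 stand against one another and against compound 1.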